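Halogen Swap Leaves Cytotoxicity Limit Unchanged

The source may hold more compounds than are shown below. What is called first, only, known or untested is meant among the compounds shown, and "the series" means these compounds.

Compound 1 `O=C1N(CCCCCCCOc2ccc(Br)cc2)CCN1c1ccncc1`: in a functional assay on cells (Homo sapiens) for cytotoxicity (on this read-out higher numbers stand for lower toxicity in this test and lower numbers for higher toxicity in this test), compound 1 gives only the limit > 25000 nM.
Compound 2 `O=C1N(CCCCCCCOc2ccc(Cl)cc2)CCN1c1ccncc1`: in this assay compound 2 gives only the limit > 25000 nM.
Compound 3 `O=C1N(CCCCCCOc2ccc(Cl)cc2)CCN1c1ccncn1`: in this assay compound 3 gives only the limit > 25000 nM.

All three measured values sit at the same limit, (the limit of > 25000 nM in this assay, at which 3 of the 3 values shown sit). The change from compound 2 to compound 1 is bromo in place of chloro on an aromatic carbon, and the step that the two limits leave unreadable from compound 2 to compound 1 cannot be read from the two limits. How the core of compound 3 differs from the core of compound 2 is not broken down here. Compound 4 `O=C1N(CCCCCCOc2ccc(Br)cc2)CCN1c1ccncn1` carries the same change, (bromo in place of chloro on an aromatic carbon). In this assay the step from compound 3 to compound 4 is expected to be a step that the limit leaves unreadable from compound 3 to compound 4, resting on the limit for compound 3, > 25000 nM, and on the unreadable step that the two limits leave unreadable from compound 2 to compound 1. Compound 4 is therefore expected to give 40000 nM, most likely again only a limit.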

Compound 4, half-maximal cytotoxic concentration: > 25000 nM
Compound 4 was reported as a limit; the forecaster's own chance of this, stated with the estimate: 85%; the middle value does not contradict the limit.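

No step can be read from compound 3 to compound 4, as both are reported only as a limit: the limit of > 25000 nM in this assay, at which 4 of the 4 values shown sit.

The compounds shown leave open how large the change from chloro to bromo is, or whether there is any change at all.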